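This account rests on a few compounds, and the source may have more. Where it says the series, first, only, none or still open, it means among the compounds named here.

Measured so far:
Compound 1 `COc1ccc(/C=C/C(=O)c2ccccc2NC(=O)NS(=O)(=O)c2ccc(C)cc2)c(OC)c1` — 16 ug/mL
Compound 2 `Cc1ccc(S(=O)(=O)NC(=O)Nc2ccccc2C(=O)/C=C/c2cccc([N+](=O)[O-])c2)cc1` — 44.5 ug/mL

In an ADME assay on the whole organism for cytotoxicity, with Artemia salina as the target, with a stated time of 24 h (on this read-out higher numbers stand for an effect only at larger amounts of compound and lower numbers for an effect already at smaller amounts), compound 2 stands at the highest of the two numbers, while compound 1 sits lower by the step of a 2.8-fold higher number from compound 1 to compound 2 (0.44 log units; beyond the scatter). Compound 3 `Cc1ccc(S(=O)(=O)NC(=O)Nc2ccccc2C(=O)/C=C/c2ccc(F)cc2)cc1` differs from compound 2 by 4-fluorophenyl in place of 3-nitrophenyl on a double-bonded chain carbon bound to a double-bonded chain carbon. Within the data shown here, that one measured step concerns a different group entering at the same place and bears on this change only loosely; no step tests the fluorophenyl itself. The expectation for compound 3 is therefore a step of a 1.4-fold lower number from compound 2 to compound 3 (0.14 log units; within the scatter) in this assay, within the scatter. Compound 3 is estimated at 32 ug/mL, with a range from 12 ug/mL to 80 ug/mL.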

Compound 3, concentration for half-maximal effect: 3.96 ug/mL
For compound 3 the middle estimate is 8.1-fold (0.91 log units) above the measured one; measured number outside the range, below it.
By their numbers in this assay, from the lowest: compound 3; then compound 1; then compound 2.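

In this assay, among these compounds, the group on a double-bonded chain carbon bound to a double-bonded chain carbon matters more than the one earlier step showed: 4-fluorophenyl in place of 3-nitrophenyl gives an 11-fold lower number from compound 2 to compound 3 (1.05 log units; beyond the scatter) and 4-fluorophenyl in place of 2,4-dimethoxyphenyl gives a 4.0-fold lower number from compound 1 to compound 3 (0.61 log units; beyond the scatter) so that compound 3 holds the lowest number of the three. Nothing available here accounts for this shift. From the compounds shown here alone, whether the fluorine itself or its place on the ring carries the change stays open, as does how a plain phenyl, a 4-chlorophenyl or a 4-aminophenyl would read here.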